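Nitro in place of methyl on the benzyl ring

The source may hold more compounds than are shown below. What is called first, only, known or untested is meant among the compounds shown, and "the series" means these compounds.

Compound 1 `COc1cccc(OC)c1OCCNCCOc1ccccc1OCc1ccccc1` gives 8.3 in a functional assay on spleen for antagonist activity at Alpha-1B adrenergic receptor (Rattus norvegicus); on this read-out lower numbers stand for lower potency and higher numbers for higher potency (the scale is a negative logarithm).
Compound 2 `COc1cccc(OC)c1OCCNCCOc1ccccc1OCc1ccccc1Cl` gives 7.52 in this assay.
Compound 3 `COc1cccc(OC)c1OCCNCCOc1ccccc1OCc1cccc(C)c1` gives 8.2 in this assay.

Compound 3 stands second of the three numbers. Its nearest neighbour is compound 1, with a number 0.10 log units lower from compound 1 to compound 3 (within the scatter), while compound 2 lies further off, with a number 0.68 log units higher from compound 2 to compound 3 (beyond the scatter). Among the compounds with values here, the one clear step among the measured compounds is a number 0.78 log units lower from compound 1 to compound 2 (beyond the scatter), a chloro entering where hydrogen stood on the same benzyl ring.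

Compound 4 `COc1cccc(OC)c1OCCNCCOc1ccccc1OCc1cccc([N+](=O)[O-])c1` differs from compound 3 in one place: nitro in place of methyl on an aromatic carbon. Within the data shown here, no measured pair shows a nitro entering anywhere, so the expectation can lean only on the two steps just named. The methyl at this place cost nothing beyond the scatter, whereas the chloro at its own place cost a modest amount. A nitro is a larger change than a methyl, so a modest loss is the more likely outcome, though a result within the scatter of compound 3 cannot be ruled out.

Compound 4 is therefore estimated at 7.9, with a range from 7.3 to 8.5, which means an expected step of a number 0.30 log units lower from compound 3 to compound 4 (within the scatter).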

Compound 4, negative logarithm of the antagonist equilibrium constant: 8.74
Compound 4: the middle estimate sits 0.84 log units below what was measured; measured number outside the range, above it.
By their numbers in this assay, from the lowest: compound 2; then compounds 3 and 1 (each within the scatter of the next); then compound 4.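

Until now this aromatic carbon had shown only tolerance, since the methyl of compound 3 stayed within the scatter of compound 1, but in this assay a nitro in place of the hydrogen gives a number 0.44 log units higher from compound 1 to compound 4 (beyond the scatter), so a group here can raise the number and not merely leave it unchanged. The outcome depends on which group sits at this carbon, as nitro in place of methyl gives a number 0.54 log units higher from compound 3 to compound 4 (beyond the scatter), while the 3-nitrophenyl in place of the 2-chlorophenyl gives a number 1.22 log units higher from compound 2 to compound 4 (beyond the scatter), and the steps from all three other compounds place compound 4 highest of the four. Nothing available here explains why the nitro raises the number.

The compounds shown leave open whether this rise is particular to the nitro or would also appear with another group at the same carbon, such as a nitrile, an amine or a carboxylic acid. They also leave open how a nitro would fare on the carbon that holds the chloro of compound 2, and how a chloro would fare on the carbon that holds the nitro of compound 4.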